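Freeing the Phenol on Two Closely Related Cores

The compounds below may be only part of what the source reports. "The series", "measured", "known", "first", "only" and "open" are said of these compounds alone.

Compound 1, `CCOC(=O)c1cc(-c2cc(OC)c(OC)c(OC)c2)c(-c2ccc(OC)c(OCc3ccccc3)c2)s1`, carries a benzyl on an oxygen on an aromatic ring and an ethyl on an oxygen next to a carbonyl group. In a functional assay on SGC-7901 cells (Homo sapiens) for antiproliferative activity, read by MTT assay, with a stated time of 72 h (a lower number here means a stronger inhibitor, a higher number a weaker inhibitor), compound 1 reaches only the limit > 100000 nM. Compound 2, `CCOC(=O)c1cc(-c2cc(OC)c(OC)c(OC)c2)c(-c2ccc(OC)c(O)c2)s1`, differs from compound 1 by hydrogen in place of benzyl on an oxygen on an aromatic ring. In this assay compound 2 gives 1580 nM, so that change made an at least 63-fold lower number from compound 1 to compound 2 (1.80 log units; beyond the scatter). Compound 3, `COc1ccc(-c2sc(C(=O)O)cc2-c2cc(OC)c(OC)c(OC)c2)cc1OCc1ccccc1`, differs from compound 1 by hydrogen in place of ethyl on an oxygen next to a carbonyl group. In this assay compound 3 also stops at the limit > 100000 nM. The change from compound 1 to compound 3 is therefore a step that the two limits leave unreadable from compound 1 to compound 3 because of the limit of > 100000 nM in this assay, at which 2 of the 3 values shown sit. Compound 4, `COc1ccc(-c2sc(C(=O)O)cc2-c2cc(OC)c(OC)c(OC)c2)cc1O`, is not yet measured and differs from compound 3 by hydrogen in place of benzyl on an oxygen on an aromatic ring, the same change seen from compound 1 to compound 2, at the same place on a core that carries the acid rather than the ester. Since the acid core itself cannot be placed against the ester core, the expected step carries wide uncertainty; still, compound 4 is expected to show an at least 6.6-fold lower number from compound 3 to compound 4 (0.82 log units; beyond the scatter), resting on an at least 63-fold lower number from compound 1 to compound 2 (1.80 log units; beyond the scatter). The expected value for compound 4 in this assay is 15000 nM, within 2000 nM to 100000 nM.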

Compound 4, half-maximal inhibitory concentration: 6100 nM
Compound 4: the middle estimate sits 2.5-fold (0.39 log units) above what was measured; measured number inside the range.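

In this assay, hydrogen in place of benzyl lowers the number on the acid core as well, with an at least 16-fold lower number from compound 3 to compound 4 (1.21 log units; beyond the scatter), so the direction of this change carries over from the ester core to the acid core. The size of the change cannot be compared between the two cores, since compound 1 and compound 3 give limits rather than numbers: the same change on two cores in this assay, an at least 63-fold lower number (1.80 log units; beyond the scatter) from compound 1 to compound 2 and an at least 16-fold lower number (1.21 log units; beyond the scatter) from compound 3 to compound 4; the limit leaves it open whether they differ With the hydroxy group free, the ester and the acid can at last be set side by side, and hydrogen in place of ethyl gives a 3.9-fold higher number from compound 2 to compound 4 (0.59 log units; beyond the scatter), whereas the same change with benzyl still in place cannot be read: the limit of > 100000 nM in this assay, at which 2 of the 4 values shown sit.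

Going by these compounds, only benzyl and hydrogen appear on this oxygen, so it remains open how a methyl group or a longer chain would behave there. Only the ethyl ester and the carboxylic acid appear at the other end of the core, which leaves open how an amide would compare when the hydroxy group is free.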